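Ester capping of the benzoic acid in a kinase series

This account rests on a few compounds, and the source may have more. Where it says the series, first, only, none or still open, it means among the compounds named here.

Measured so far:
compound 1, `NCc1ccc(C(=O)Nc2ccncc2F)cc1-c1cccc(NC(=O)c2cccc(C(=O)O)c2)c1`: < 1 nM
compound 2, `NCc1ccc(C(=O)Nc2ccncc2F)cc1-c1cccc(NC(=O)c2cc(C(=O)O)ccc2F)c1`: < 1 nM

In an assay on cells for inhibition of Rho-associated protein kinase 2 (Homo sapiens), read by radiometric assay and 33P incorporation, in the presence of a further agent that is not named here (a lower number here means a stronger inhibitor, a higher number a weaker inhibitor), compound 1 gives < 1 nM, a limit of the assay rather than a number. Compound 2 gives < 1 nM in this assay, likewise a limit. The step that the two limits leave unreadable from compound 1 to compound 2 is therefore unreadable, both values sitting at the limit of < 1 nM in this assay, at which 2 of the 2 values shown sit. Compound 3 `COCCOC(=O)c1ccc(F)c(C(=O)Nc2cccc(-c3cc(C(=O)Nc4ccncc4F)ccc3CN)c2)c1` carries 2-methoxyethyl in place of hydrogen on an oxygen next to a carbonyl group. Going by the values given here, no measured step bears on this change, and compound 2 stands only at a limit, so the size of an at least 3.0-fold higher number from compound 2 to compound 3 (0.47 log units; beyond the scatter) is expected to be at most a modest weakening. Compound 3 is estimated at 3 nM, within 0.5 nM to 30 nM.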

Compound 3, half-maximal inhibitory concentration: < 1 nM
Compound 3: a limit, no number (the forecaster's own chance of this, stated with the estimate: 30%); middle value at least 3.0-fold (0.47 log units) away from the limit.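

Compound 2 and compound 3 both sit at a limit, so the step between them cannot be read: the limit of < 1 nM in this assay, at which 3 of the 3 values shown sit.

The compounds shown leave open how large any change from the fluoro or 2-methoxyethyl replacement is in this assay.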